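The source may report more compounds than this note shows. Statements on the series, on what has been measured and on what is new or still open speak of the compounds shown alone.

Measured so far in a functional assay on SK-BR-3 cells (Homo sapiens) for antiproliferative activity, read by MTT assay, with a stated time of 72 h; a higher number here means a weaker inhibitor, a lower number a stronger inhibitor: compound 1 `CC(Nc1ncnc2ccc(-c3cnn(C4CCNCC4)c3)cc12)c1c(Cl)ccc(F)c1Cl` gives 4390 nM; compound 2 `CC(Nc1nc(N)nc2ccc(-c3cnn(C4CCNCC4)c3)cc12)c1c(Cl)ccc(F)c1Cl` gives 1580 nM; compound 3 `CC(Nc1ncnc2ncc(-c3cnn(C4CCNCC4)c3)cc12)c1c(Cl)ccc(F)c1Cl` gives 17700 nM.

Compound 1 stands second highest of these three numbers. Its nearest neighbour is compound 2, the step being a 2.8-fold lower number from compound 1 to compound 2 (0.44 log units; beyond the scatter); its furthest is compound 3, whose number is higher still.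

Compound 4 `c1cnc2ccc(Nc3ncnc4ccc(-c5cnn(C6CCNCC6)c5)cc34)cc2c1` differs from compound 1 by quinolin-6-yl in place of 1-(2,6-dichloro-3-fluorophenyl)ethyl on a nitrogen on an aromatic ring. Going by the values given here, no measured step touches this nitrogen: the one step in hand, a 2.8-fold lower number from compound 1 to compound 2 (0.44 log units; beyond the scatter), concerns a change elsewhere on the core, and compound 3 differs from compound 1 in the core itself. The exchange at the nitrogen is therefore unanchored, and the size and direction of the step in this assay are open; a wide range is set. Compound 4 is estimated at 12000 nM (2500 nM to 60000 nM), which would be expected to mean a 2.7-fold higher number from compound 1 to compound 4 (0.44 log units; beyond the scatter).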

Compound 4, half-maximal inhibitory concentration: 2660 nM
Compound 4: the middle estimate sits 4.5-fold (0.65 log units) above what was measured; low and high end bracket the measured number.
By their numbers in this assay, from the lowest: compounds 2, 4 and 1 (each within the scatter of the next, the first and the last beyond it); then compound 3.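

In this assay, quinolin-6-yl in place of 1-(2,6-dichloro-3-fluorophenyl)ethyl on the nitrogen gives a 1.7-fold lower number from compound 1 to compound 4 (0.22 log units; within the scatter), so this exchange leaves the number within the scatter. On the core of compound 1, the halogenated group is therefore not required for a number of this size, even though the entering group differs in its rings and adds a hydrogen-bond acceptor. Nothing on hand gives a reason for this result.

On these data alone, whether quinolin-6-yl gives a similar step on the cores of compound 2 and compound 3 stays open. Also open, as far as these compounds go, is how an unsubstituted phenyl, a benzyl or an aminoalkyl chain on this nitrogen would compare.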